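The source may hold more compounds than are shown below. What is called first, only, known or untested is meant among the compounds shown, and "the series" means these compounds.

Measured compounds:
- Compound 1 `C=CCOc1ccc(C(=O)Nc2cccc(C)n2)cc1` — 31700 nM in an in vitro assay on HEK-tsA201 cells for antagonist activity at Neuronal acetylcholine receptor; alpha3/beta4 (Homo sapiens), read by fluorescence and calcium flux; on this read-out higher numbers stand for weaker inhibition and lower numbers for stronger inhibition
- Compound 2 `C#CCOc1ccc(C(=O)Nc2cccc(C)n2)cc1` — 21700 nM in this assay

On the numbers shown, compound 1 stands highest of the two, with compound 2 nearest, where the only measured step is a 1.5-fold lower number from compound 1 to compound 2 (0.16 log units; within the scatter), a change on the ether chain rather than on the ring. Compound 3 `C=CCOc1ccc(C(=O)Nc2cccc(NCCC)n2)cc1` differs from compound 1 by propylamino in place of methyl on an aromatic carbon. For the measured compounds named here, no measured step touches this site, so the step gives no guide to direction, and a step no larger than the scatter is expected as a 1.3-fold lower number from compound 1 to compound 3 (0.10 log units; within the scatter). Compound 3 is therefore estimated at 25000 nM, within 8000 nM to 80000 nM.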

Compound 3, half-maximal inhibitory concentration: 11700 nM
For compound 3 the middle estimate is 2.1-fold (0.33 log units) above the measured one, and the stated range covers the measured number.
By their numbers in this assay, from the lowest: compounds 3, 2 and 1 (each within the scatter of the next, the first and the last beyond it).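

Swapping methyl for propylamino on this aromatic carbon gives a 2.7-fold lower number from compound 1 to compound 3 (0.43 log units; beyond the scatter) in this assay, the first step shown that lies beyond the scatter, whereas the change on the ether chain stayed within it. The position next to the ring nitrogen therefore accepts a larger group carrying a nitrogen without any rise in the number. Nothing available explains this step. Whether the nitrogen or the propyl chain accounts for it remains open, and a primary amine or a butyl chain here would help separate the two. Also open, going by these compounds, is whether propylamino gives a similar step alongside the propargyl ether of compound 2.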